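The compounds below may be only part of what the source reports. "The series", "measured", "known", "first", "only" and "open" are said of these compounds alone.

Working notes on the series, all read in a functional assay on B16 cells (Mus musculus) for inhibition, with a stated time of 72 h; on this read-out higher numbers stand for weaker inhibition and lower numbers for stronger inhibition. Compound 1 (`COc1ccc(CN2CCNC2=S)cc1`) gives > 10000 nM, which is a limit of the assay and not a number. Among the compounds with values here, compound 2 (`S=C1NCCN1CCCc1ccccc1`) gives 4200 nM, the one true number so far. Compound 3 (`S=C1NCCCN1Cc1ccccc1`) gives > 10000 nM, also a limit and not a number. Compound 3 thus stands at the limit of > 10000 nM in this assay, at which 2 of the 3 values shown sit.

Compound 4 (`Cc1ccc(CN2CCCNC2=S)cc1`) differs from compound 3 in one place: methyl in place of hydrogen on an aromatic carbon. That is methyl in place of hydrogen on an aromatic carbon, para to a group of 8 heavy atoms. Within the data shown here, no measured pair shows a change of this kind, so the data give no size for it. Among the measured compounds shown here, the only anchor is compound 3, with its limit of > 10000 nM. The expected step that the limit leaves unreadable from compound 3 to compound 4 in this assay is none beyond the scatter, with no direction favoured. Compound 4 is estimated at 12000 nM, with an expected range of 5000 nM to 25000 nM.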

Compound 4, half-maximal inhibitory concentration: 5100 nM
Estimate against measurement, compound 4: 2.4-fold (0.37 log units) above; measured number inside the range.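

In this assay, methyl in place of hydrogen on an aromatic carbon, para to a group of 8 heavy atoms, gives an at least 1.9-fold lower number from compound 3 to compound 4 (0.29 log units; that floor lies within the scatter). Within the data shown here, compound 4 is thus the first compound on the core of compound 3 to give a true number rather than a limit of the assay. Only a floor can be read for this step, and its full size stays unknown, because compound 3 carries a limit and not a number: the limit of > 10000 nM in this assay, at which 2 of the 4 values shown sit.

As far as these compounds go, whether chlorine, an amine or a carboxylic acid at the same place would move the number in the same direction remains open. Also open, from the compounds shown here alone, is whether methyl at this place would have any effect on the core of compound 2.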